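Replacing the methoxyphenyl by a furyl group: an expectation

The compounds below may be only part of what the source reports. "The series", "measured", "known", "first", "only" and "open" are said of these compounds alone.

In a functional assay on T47D cells (Homo sapiens) for inhibition, read by MTT assay, with a stated time of 48 h (a lower number here means a stronger inhibitor, a higher number a weaker inhibitor), three compounds have been measured. Compound 1 `CCOC(=O)c1c(N)sc(/N=C/c2ccc(N(C)C)cc2)c1C(=O)OCC` gives 16700 nM. Compound 2 `CCOC(=O)c1c(N)sc(/N=C/c2ccc(OC)cc2)c1C(=O)OCC` gives 31900 nM. Compound 3 `CCOC(=O)c1c(N)sc(/N=C/c2ccncc2)c1C(=O)OCC` gives 8600 nM.

Compound 2 has the highest number of the three. Its gap to compound 1 is small: a 1.9-fold higher number from compound 1 to compound 2 (0.28 log units; within the scatter). Its gap to compound 3 is larger: a 3.7-fold lower number from compound 2 to compound 3 (0.57 log units; beyond the scatter). Compound 1 and compound 3 also lie close to each other, as a 1.9-fold lower number from compound 1 to compound 3 (0.29 log units; within the scatter) shows.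

Compound 4 `CCOC(=O)c1c(N)sc(/N=C/c2ccco2)c1C(=O)OCC` has not been measured. Its difference from compound 2 is furan-2-yl in place of 4-methoxyphenyl on a carbon with a double bond to nitrogen. Among the compounds with values here, the one measured step that bears on this change is the one in which the aromatic ring on the carbon with a double bond to nitrogen was exchanged for a ring containing a hetero atom, a 3.7-fold lower number from compound 2 to compound 3 (0.57 log units; beyond the scatter), which gave a modest lowering of the number. The step of a 1.9-fold lower number from compound 1 to compound 3 (0.29 log units; within the scatter) shows that a second such exchange stayed within the scatter. A furan-2-yl is a different ring again, so the outcome is uncertain; a modest lowering, or no step beyond the scatter, is expected.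

For compound 4 the estimated value in this assay is 15000 nM, between 5000 nM and 45000 nM, which is expected to correspond to a 2.1-fold lower number from compound 2 to compound 4 (0.33 log units; beyond the scatter).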

Compound 4, half-maximal inhibitory concentration: 14900 nM
For compound 4 the middle estimate is 1.0-fold (0.00 log units) above the measured one; low and high end bracket the measured number.
By their numbers in this assay, from the lowest: compounds 3, 4, 1 and 2 (each within the scatter of the next, the first and the last beyond it).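

Within the data shown here, the change from 4-methoxyphenyl to furan-2-yl, on the carbon with a double bond to nitrogen, brings a five-membered aromatic ring into a series that had so far carried only six-membered rings at this place, and in this assay the step is beyond the scatter but modest (a 2.1-fold lower number from compound 2 to compound 4 (0.33 log units; beyond the scatter)). The furan-2-yl compound cannot be told apart from the pyridin-4-yl compound (a 1.7-fold higher number from compound 3 to compound 4 (0.24 log units; within the scatter)), nor from the 4-(dimethylamino)phenyl compound (a 1.1-fold lower number from compound 1 to compound 4 (0.05 log units; within the scatter)). A five-membered ring therefore fits at this place without a step beyond the scatter from either of these two, so ring size alone does not separate compound 4 from them, although this rests on only four compounds and compound 1 itself lies within the scatter of compound 2.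

As far as these compounds go, it remains open how the number would respond to a thiophene ring, a phenyl ring carrying a carboxylic acid, or an open alkyl chain at this place, and whether the two ethyl esters of the shared core matter at all. Nothing in the data shown explains why the number moves with this ring change.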